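The compounds below may be only part of what the source reports. "The series", "measured", "known", "first", "only" and "open" are said of these compounds alone.

In an ADME assay on BJ cells (Homo sapiens) for cytotoxicity, read by luminescence, with a stated time of 72 h (a lower number here means that less compound is needed, a higher number that more compound is needed for the effect), three compounds on a shared core have been measured, and none of them yields a number. Compound 1 `C=Cc1cccc(-c2[nH]c3cc(OC)ccc3c(=O)c2C(=O)OCC)c1` carries vinyl and reads > 21500 nM as a limit of the assay. Compound 2 `CCOC(=O)c1c(-c2cccc(OCC)c2)[nH]c2cc(OC)ccc2c1=O` carries ethoxy and reads > 21500 nM as a limit too. Compound 3 `CCOC(=O)c1c(-c2cccc(OCc3ccccc3)c2)[nH]c2cc(OC)ccc2c1=O` carries benzyloxy and reads > 21500 nM as a limit as well. It therefore stands with the other two at the limit of > 21500 nM in this assay, at which 3 of the 3 values shown sit, and has no number of its own.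

The next compound, compound 4 `CCOC(=O)c1c(-c2cccc(F)c2)[nH]c2cc(OC)ccc2c1=O`, has fluoro in place of benzyloxy on an aromatic carbon, and the change counts as follows: fluoro in place of benzyloxy on an aromatic carbon (the same carbon that carries vinyl and ethoxy in the other two). Going by the values given here, the steps that bear on it are a step that the two limits leave unreadable from compound 1 to compound 2 and a step that the two limits leave unreadable from compound 1 to compound 3 and a step that the two limits leave unreadable from compound 2 to compound 3 and none of them has a readable size.

Because the limit of > 21500 nM in this assay, at which 3 of the 3 values shown sit, holds for every compound measured, no readable step is expected in this assay and no direction can be given. The expected step is a step that the limit leaves unreadable from compound 3 to compound 4 and it rests on limits alone. For compound 4 the estimated value is 30000 nM with an expected range from 15000 nM to 60000 nM and a report as a limit is the likeliest outcome.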

Compound 4, half-maximal effective concentration: > 21500 nM
Compound 4 ended at the assay's limit; the forecaster's own chance of this, stated with the estimate: 85%; the middle value does not contradict the limit.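

No new step can be read for compound 4 against compound 1, compound 2 or compound 3 in this assay, because all four compounds share one assay limit: the limit of > 21500 nM in this assay, at which 4 of the 4 values shown sit.

The compounds shown leave open whether vinyl, ethoxy, benzyloxy and fluoro differ at all in this assay, and whether any compound on the shared core would give a number there.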